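Swapping the aryl ether on a dipeptide-like inhibitor

A few compounds are considered here, and "the series" means these few. Any claim that something is new, unique, unknown or untested is made for them only; others in the source may bear on it.

Three compounds share one core and differ only in the aryl group attached through an oxygen on a saturated carbon. Compound 1 `CC(C)[C@H](NC(=O)COc1cccc2ccccc12)C(=O)N[C@@H](CC(=O)O)C(=O)COc1cccc(C(F)(F)F)c1` carries 3-(trifluoromethyl)phenyl there; in a functional assay with Homo sapiens as the target (a higher number here means a weaker inhibitor, a lower number a stronger inhibitor), compound 1 gives 16600 nM. Compound 2 `CC(C)[C@H](NC(=O)COc1cccc2ccccc12)C(=O)N[C@@H](CC(=O)O)C(=O)COc1ccccc1F` carries 2-fluorophenyl and gives 15700 nM, while compound 3 `CC(C)[C@H](NC(=O)COc1cccc2ccccc12)C(=O)N[C@@H](CC(=O)O)C(=O)COc1ccc(F)cc1` carries 4-fluorophenyl and gives 14300 nM. Among the measured compounds shown here, compound 1 has the largest of the three numbers, but the gaps to the other two are within the scatter, so no compound stands apart.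

Compound 4 `CC(C)[C@H](NC(=O)COc1cccc2ccccc12)C(=O)N[C@@H](CC(=O)O)C(=O)COc1ccc(F)c(F)c1` has not yet been measured. Relative to compound 1 it differs as follows: 3,4-difluorophenyl in place of 3-(trifluoromethyl)phenyl on an oxygen on a saturated carbon. For the measured compounds named here, the steps that bear on this are a 1.1-fold lower number from compound 1 to compound 2 (0.02 log units; within the scatter) and a 1.2-fold lower number from compound 1 to compound 3 (0.06 log units; within the scatter), both of them within the scatter; likewise a 1.1-fold lower number from compound 2 to compound 3 (0.04 log units; within the scatter). Every exchange of the aryl ether tried so far has left this assay essentially unchanged, so a step from compound 1 to compound 4 of no more than the scatter is expected, that is a 1.1-fold lower number from compound 1 to compound 4 (0.06 log units; within the scatter). Compound 4 is therefore estimated at 14500 nM, with a range from 8000 nM to 28000 nM.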

Compound 4, half-maximal inhibitory concentration: 16200 nM
Compound 4: middle estimate off by 1.1-fold (0.05 log units), on the low side, within the range that was stated.
By their numbers in this assay, from the lowest: compounds 3, 2, 4 and 1 (each within the scatter of the next).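

Fluoro in place of hydrogen on an aromatic carbon is a smaller edit than the earlier swaps of the whole aryl group, and in this assay it gives a 1.1-fold higher number from compound 3 to compound 4 (0.05 log units; within the scatter) and so stays within the scatter. The 3,4-difluorophenyl group also matches the other groups within the scatter, with a 1.0-fold lower number from compound 1 to compound 4 (0.01 log units; within the scatter) and a 1.0-fold higher number from compound 2 to compound 4 (0.01 log units; within the scatter), so all four fluorinated phenyl groups on this oxygen read alike in this assay. Nothing on hand explains why this position accepts these exchanges.

On these data alone, all four groups are fluorinated phenyl rings, so it remains open whether a phenyl ring bearing an amine or a nitrile, or a butyl chain in place of the ring, would read the same. As far as these compounds go, it also remains open whether changes to the shared core would move these numbers.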